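The source may report more compounds than this note shows. Statements on the series, on what has been measured and on what is new or still open speak of the compounds shown alone.

Measured compounds:
- Compound 1, `O[C@@H]1Cc2cc(Br)ccc2N[C@H](c2ccccc2)C1`: in an ADME assay on Vero cells (Chlorocebus sabaeus) for cytotoxicity, read by MTT assay, with a stated time of 72 h (a higher number here means that more compound is tolerated, a lower number that less compound is tolerated), compound 1 gives 42100 nM.
- Compound 2, `O[C@@H]1Cc2cc(F)ccc2N[C@H](c2ccccc2)C1`: in this assay compound 2 gives > 300000 nM, which is a limit of the assay and not a number.

Going by the values given here, compound 2 therefore stands at the upper bound of this assay, and the one measured step, an at least 7.1-fold higher number from compound 1 to compound 2 (0.85 log units; beyond the scatter), ends at that bound (the limit of > 300000 nM in this assay, at which 1 of the 2 values shown sits). Compound 3, `O[C@@H]1Cc2cc(F)ccc2N[C@H](c2ccc(Cl)cc2)C1`, is the next step from compound 2: chloro in place of hydrogen on an aromatic carbon. Among the compounds with values here, no measured step bears on this change; the single step known is a halogen exchange on the other aromatic ring and offers no direct precedent for adding a group. A step in this assay from compound 2 to compound 3 is thus expected to be small or none beyond the scatter, with a lower number somewhat more likely than a higher one, as compound 2 is already a limit. The expected value for compound 3 is 200000 nM, between 60000 nM and 400000 nM. This expected step is an at least 1.5-fold lower number from compound 2 to compound 3 (0.17 log units; that floor lies within the scatter).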

Compound 3, half-maximal cytotoxic concentration: 194000 nM
Estimate against measurement, compound 3: 1.0-fold (0.01 log units) above; measured number inside the range.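

Adding chloro on the six-membered aromatic ring of carbon only, para to a large group, gives in this assay an at least 1.5-fold lower number from compound 2 to compound 3 (0.18 log units; that floor lies within the scatter). Going by these compounds alone, this is the first look at this ring, since the earlier step concerned only the halogen on the other aromatic ring, and compound 3 gives this position a measured starting value instead of a limit. The true size of the step cannot be read because compound 2 sits at a limit and not at a number: the limit of > 300000 nM in this assay, at which 1 of the 3 values shown sits.

Going by these compounds, it remains open whether a group other than a halogen at this place, such as an amine, a methoxy group or a carboxylic acid, would move the number beyond the scatter. Also open, on these data alone, is whether chloro here behaves the same way with bromo rather than fluoro on the other aromatic ring.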